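Swapping 2-methylphenyl for 4-chlorophenyl on the shared core

A few compounds are considered here, and "the series" means these few. Any claim that something is new, unique, unknown or untested is made for them only; others in the source may bear on it.

Compound 1 `Cc1ccsc1-c1cc(-c2ccco2)cc(-c2ccccc2Cl)n1`: 25400 nM
Compound 2 `Cc1ccccc1-c1cc(-c2ccoc2)cc(-c2ccc(Cl)s2)n1`: 12300 nM

In a functional assay on K562 cells (Homo sapiens) for cytotoxicity, read by ELISA, with a stated time of 4 days (on this read-out higher numbers stand for weaker inhibition and lower numbers for stronger inhibition), compound 2 gives the lower of the two numbers, 12300 nM, while compound 1 stands higher at 25400 nM, a gap just beyond the usual scatter. Compound 3 `Clc1ccc(-c2cc(-c3ccoc3)cc(-c3ccc(Cl)s3)n2)cc1` differs from compound 2 by 4-chlorophenyl in place of 2-methylphenyl on an aromatic carbon. For the measured compounds named here, no measured pair isolates this change, so the expectation is loose. No step beyond the scatter is expected, the estimated step being a 1.2-fold lower number from compound 2 to compound 3 (0.09 log units; within the scatter). For compound 3 the estimated value is 10000 nM, with an expected range of 4000 nM to 25000 nM.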

Compound 3, half-maximal inhibitory concentration: 19600 nM
For compound 3 the middle estimate is 2.0-fold (0.29 log units) below the measured one; the range from low to high includes it.
By their numbers in this assay, from the lowest: compounds 2, 3 and 1 (each within the scatter of the next, the first and the last beyond it).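

In this assay, for the compounds shown here, the first comparison confined to one place gives a 1.6-fold higher number from compound 2 to compound 3 (0.20 log units; within the scatter), as 2-methylphenyl leaves and 4-chlorophenyl enters. On this aromatic carbon next to the ring nitrogen, the two groups are therefore not told apart by this read-out, with the 5-chlorothiophen-2-yl and furan-3-yl groups held constant. Nothing available explains this result. The compounds shown leave open whether an amine or a carboxylic acid on this carbon would give a step beyond the scatter. They also leave open whether this swap would read the same with another group in place of the furan-3-yl group.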